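Swapping a ring for an open group at the chain end

This account rests on a few compounds, and the source may have more. Where it says the series, first, only, none or still open, it means among the compounds named here.

Values measured in a functional assay on SK-BR-3 cells (Homo sapiens) for antiproliferative activity (a lower number here means a stronger inhibitor, a higher number a weaker inhibitor), are these
Compound 1 `CC(C)=CCc1cc(C(=O)Nc2cc3ccc(OCC4CCCN(C)C4)c(C)c3oc2=O)ccc1O` gives 1300 nM 
Compound 2 `CC(C)=CCc1cc(C(=O)Nc2cc3ccc(OCCCN4CCCC4)c(C)c3oc2=O)ccc1O` gives 720 nM 

Compound 2 and compound 1 lie within the scatter of each other, so neither can be ranked over the other. Compound 3 `CCN(CC)CCCOc1ccc2cc(NC(=O)c3ccc(O)c(CC=C(C)C)c3)c(=O)oc2c1C` differs from compound 2 in one place diethylamino in place of pyrrolidin-1-yl on a saturated chain carbon, three bonds along the chain from an oxygen on an aromatic ring with diethylamino in place of pyrrolidin-1-yl on a saturated chain carbon, three bonds along the chain from an oxygen on an aromatic ring. Among the compounds with values here, only one measured step bears on this, and only loosely, since it swaps a different group: a 1.8-fold lower number from compound 1 to compound 2 (0.26 log units; within the scatter) stays inside the scatter. No measurement covers this exact swap, so no change beyond the scatter is expected in this assay here. The expected step is a 1.1-fold higher number from compound 2 to compound 3 (0.05 log units; within the scatter) and no more. Compound 3 is therefore estimated at 800 nM with an expected range from 350 nM to 1800 nM in this read-out.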

Compound 3, half-maximal inhibitory concentration: 4900 nM
For compound 3 the middle estimate is 6.1-fold (0.79 log units) below the measured one; the measured number lies above the stated range.
By their numbers in this assay, from the lowest: compounds 2 and 1 (each within the scatter of the next); then compound 3.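

In this assay, opening the ring at the chain end does change the result: there is a 6.8-fold higher number from compound 2 to compound 3 (0.83 log units; beyond the scatter) even though pyrrolidin-1-yl and diethylamino have the same heavy atoms and differ in whether those atoms form a ring. The earlier pair, both with a ring in the side chain, lay within the scatter of each other, and the open group also compares poorly with the piperidine-bearing side chain, with a 3.8-fold higher number from compound 1 to compound 3 (0.58 log units; beyond the scatter) as the result. No measurement available here explains this loss.

The compounds shown leave open whether other open amines, such as dimethylamino, behave like diethylamino. They also leave open whether a piperidin-1-yl or morpholin-4-yl group on the same propyl chain would stay close to pyrrolidin-1-yl.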